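The compounds below may be only part of what the source reports. "The series", "measured", "known", "first", "only" and "open" are said of these compounds alone.

In a functional assay on A549 cells (Homo sapiens) for antiproliferative activity, read by MTT assay (on this read-out lower numbers stand for stronger inhibition and higher numbers for weaker inhibition), the measured compounds stand thus. Compound 1 `Cn1c(=O)c(=O)n(C2CCCC2)c2nc(N/N=C/c3ccc(Cl)cc3)ncc21` gives 6890 nM. Compound 2 `Cn1c(=O)c(=O)n(C2CCCC2)c2nc(N/N=C/c3ccc(F)cc3Cl)ncc21` gives 11000 nM. Compound 3 `COc1ccc(/C=N/Nc2ncc3c(n2)n(C2CCCC2)c(=O)c(=O)n3C)cc1` gives only > 100000 nM, a limit of this assay rather than a number. Its value is the one sitting at the limit of > 100000 nM in this assay, at which 1 of the 3 values shown sits, so compound 3 is the weakest of the three, as an at least 14-fold higher number from compound 1 to compound 3 (1.16 log units; beyond the scatter) and an at least 9.0-fold higher number from compound 2 to compound 3 (0.95 log units; beyond the scatter) show, while a 1.6-fold higher number from compound 1 to compound 2 (0.20 log units; within the scatter) stays within the scatter.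

Compound 4 `Cn1c(=O)c(=O)n(C2CCCC2)c2nc(N/N=C/c3ccccc3Cl)ncc21` differs from compound 3 in one place: 2-chlorophenyl in place of 4-methoxyphenyl on a carbon with a double bond to nitrogen. This runs the measured steps backwards, returning to a chlorine-bearing ring as in compound 1 and compound 2, the latter already carrying its chlorine in the 2-position. A downward step of that order is therefore expected, roughly an at least 6.6-fold lower number from compound 3 to compound 4 (0.82 log units; beyond the scatter). Compound 4 is estimated at 15000 nM, between 5000 nM and 60000 nM.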

Compound 4, half-maximal inhibitory concentration: 9860 nM
Estimate against measurement, compound 4: 1.5-fold (0.18 log units) above, and the stated range covers the measured number.
By their numbers in this assay, from the lowest: compounds 1, 4 and 2 (each within the scatter of the next). At a limit, above all of these: compound 3.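

With 2-chlorophenyl in place of 4-methoxyphenyl on this carbon, this assay shows an at least 10-fold lower number from compound 3 to compound 4 (1.00 log units; beyond the scatter). Compound 3 stands at a limit of the assay rather than at a number: the limit of > 100000 nM in this assay, at which 1 of the 4 values shown sits.

Hydrogen in place of fluoro gives a 1.1-fold lower number from compound 2 to compound 4 (0.05 log units; within the scatter), and 2-chlorophenyl in place of 4-chlorophenyl gives a 1.4-fold higher number from compound 1 to compound 4 (0.16 log units; within the scatter), so these three chlorine-bearing compounds cannot be told apart here.

Still open, from the compounds shown here alone, is whether the gap belongs to methoxy alone. Going by these compounds, how a phenyl ring carrying an amine or a carboxylic acid would read at this carbon also remains unknown.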